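Removing One Fluoro from Compound 1

The source may hold more compounds than are shown below. What is called first, only, known or untested is meant among the compounds shown, and "the series" means these compounds.

Measured compounds and their values:
compound 1 `O=C(O)Cc1sc(C(c2ccc(F)cc2)c2ccc(F)cc2)nc1-c1ccnc(F)c1` — 80%
compound 2 `O=C(O)Cc1sc(NC(=O)c2ccccc2)nc1-c1ccc(Cl)cc1` — 50%
compound 3 `COc1ccc(C(c2ccccn2)c2nc(-c3ccc(Cl)cc3)c(CC(=O)O)s2)cc1` — 80%

These three compounds share a core and were tested in an in vitro functional assay on HEK285-7 cells for antagonist activity at prostaglandin D2 receptor 2 (Homo sapiens), read by BRET and beta-arrestin recruitment; on this read-out lower numbers stand for smaller maximal responses and higher numbers for larger maximal responses. Compound 1 stands level with compound 3 at the digits shown, a gap within the usual scatter, and the two are together the highest of the three numbers. Compound 2 sits clearly lower, a gap beyond the scatter.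

The next compound, compound 4 `O=C(O)Cc1sc(C(c2ccc(F)cc2)c2ccc(F)cc2)nc1-c1ccncc1`, is not yet measured. It differs from compound 1 in one place: hydrogen in place of fluoro on an aromatic carbon. Among the compounds with values here, no measured pair shows this exact change, so its effect is unknown. For compound 4 the expected result is a step of no change at the digits printed from compound 1 to compound 4 (within the scatter), that is, no change beyond the scatter in either direction. Compound 4 is therefore estimated at 80%, in a range from 65% to 95%.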

Compound 4, largest response reached (reported as efficacy), in percent of the reference or control that the assay uses: 80%
The estimate for compound 4 equals the measured number at the digits printed; the range from low to high includes it.
By their numbers in this assay, from the lowest: compound 2; then compounds 1, 3 and 4 (each within the scatter of the next).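

Going from 2-fluoropyridin-4-yl to pyridin-4-yl in this assay gives no change at the digits printed from compound 1 to compound 4 (within the scatter) and is the first direct reading of a single change, as no earlier pair differed in only one place. At this position, next to the ring nitrogen, losing the fluoro leaves the maximal response in place. Nothing available explains this result. On these data alone, whether an amine, a nitrile or a methyl group on the same carbon would also leave the response in place remains open.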